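Aryl variation at the triazole nitrogen: cytotoxicity working notes

The source may hold more compounds than are shown below. What is called first, only, known or untested is meant among the compounds shown, and "the series" means these compounds.

Measured so far:
compound 1 `CC(=O)Nc1ccc(-n2nncc2CN2C(=O)C3(C(C#N)=C(N)Oc4c3c3nc5ccccc5nc3c3ccccc43)c3ccccc32)cc1` — > 50000 nM
compound 2 `N#CC1=C(N)Oc2c(N)cc3nc4ccccc4nc3c2C12C(=O)N(Cc1cnnn1-c1ccc(Cl)cc1)c1ccccc12` — > 50000 nM

In an ADME assay on L02 cells (Homo sapiens) for antiproliferative activity, read by MTT assay, with a stated time of 48 h (a lower number here means a stronger inhibitor, a higher number a weaker inhibitor), compound 1 returns only the assay limit, > 50000 nM. Compound 2 likewise returns only the assay limit, > 50000 nM. Both values shown therefore sit at the same limit (the limit of > 50000 nM in this assay, at which 2 of the 2 values shown sit), so compound 2 stands nowhere distinct among them. Compound 3 `Cc1ccc(-n2nncc2CN2C(=O)C3(C(C#N)=C(N)Oc4c(N)cc5nc6ccccc6nc5c43)c3ccccc32)cc1Cl` carries 3-chloro-4-methylphenyl in place of 4-chlorophenyl on an aromatic nitrogen. For the measured compounds named here, no measured step exists for such a change here, so no shift beyond the scatter is expected. Compound 3 is expected to give 50000 nM, within 20000 nM to 100000 nM, most probably again as a limit. The expected step is a number no higher from compound 2 to compound 3 (the limit leaves the size open).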

Compound 3, half-maximal inhibitory concentration: > 50000 nM
Compound 3 ended at the assay's limit (the forecaster's own chance of this, stated with the estimate: 80%); the middle value lies on the limit itself.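

Compound 2 and compound 3 give no readable step, as both end at the same assay limit: the limit of > 50000 nM in this assay, at which 3 of the 3 values shown sit. The compounds shown leave open whether any aryl group on the aromatic nitrogen brings a value off this limit.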